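The source may hold more compounds than are shown below. What is called first, only, known or untested is meant among the compounds shown, and "the series" means these compounds.

Working notes on a small set of tri-acid amphiphiles measured in an ADME assay on cells (Epithelial cell, Homo sapiens) for cytotoxicity, read by MTT assay; a higher number here means that more compound is needed for the effect, a lower number that less compound is needed. Compound 1 `CCCCCCCCCCCCCCCCCCCCCCOC(=O)NC(CCC(=O)O)(CCC(=O)O)CCC(=O)O` gives 360000 nM, and compound 2 `CCCCCCCCCCCCCCCCCCOC(=O)NC(CCC(=O)O)(CCC(=O)O)CCC(=O)O` gives 350000 nM. The pair differ only by butyl in place of hydrogen on a saturated chain carbon, ten or more bonds along the chain from an oxygen next to a carbonyl group, and the step is a 1.0-fold higher number from compound 2 to compound 1 (0.01 log units; within the scatter). Compound 3 `CCCCCCCCCCCCCCCC(=O)NC(CCC(=O)O)(CCC(=O)O)CCC(=O)O` gives 940000 nM, the highest number of the three measured; its difference from compound 2 is not broken down here. Compound 4 `CCCCCCCCCCCCCCCCCCCC(=O)NC(CCC(=O)O)(CCC(=O)O)CCC(=O)O` is not yet measured. It differs from compound 3 by butyl in place of hydrogen on a saturated chain carbon, ten or more bonds along the chain from a carbonyl carbon, which is the same kind of change as that from compound 2 to compound 1, though here the place is reckoned from a carbonyl carbon rather than from an oxygen next to a carbonyl group. Because the earlier step was a 1.0-fold higher number from compound 2 to compound 1 (0.01 log units; within the scatter), the expected step for the new pair is no change at the digits printed from compound 3 to compound 4 (within the scatter), i.e. compound 4 is expected to sit close to compound 3. Within the data shown here, the estimate for compound 4 in this assay is therefore 940000 nM, with a range of 450000 nM to 1900000 nM, resting on the single precedent and the modest spread among the three measured compounds.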

Compound 4, half-maximal effective concentration in the Epithelial cell assay: 340000 nM
Estimate against measurement, compound 4: 2.8-fold (0.44 log units) above; measured number outside the range, below it.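

In the Epithelial cell assay compound 3 gives 940000 nM and compound 4 gives 340000 nM. In the Epithelial cell assay, butyl in place of hydrogen on a saturated chain carbon, ten or more bonds along the chain from a carbonyl carbon, gives a 2.8-fold lower number from compound 3 to compound 4 (0.44 log units; beyond the scatter), a modest step, so the change does not carry over at one size from one core to the other: the same change on two cores in the Epithelial cell assay, a 1.0-fold higher number (0.01 log units; within the scatter) from compound 2 to compound 1 and a 2.8-fold lower number (0.44 log units; beyond the scatter) from compound 3 to compound 4, 2.8-fold (0.45 log units) apart, beyond the scatter of two such steps

This shows that a step read on one core in this series is not a safe guide to the same change on the other, but it does not show why the two cores part, and each core rests on a single pair, so no general rule follows. In a physicochemical assay for solubility, in phosphate buffer, at pH 7.2 (a lower number here means a less soluble compound, a higher number a more soluble compound), compound 3 gives 79000 nM and compound 4 gives 79000 nM. In the physicochemical assay the same change gives no change at the digits printed from compound 3 to compound 4 (within the scatter), a single pair that offers no comparison between the cores.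

The compounds shown leave open whether the gap between the two cores persists with a longer chain on either core. Also open, going by these compounds, is how either core would respond to a chain carrying an amine or a hydroxyl group.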